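Swapping a ring side chain for an amide in a nitro-thiazinone series

The compounds below may be only part of what the source reports. "The series", "measured", "known", "first", "only" and "open" are said of these compounds alone.

Compound 1 `O=c1nc(N2CCN(CC3CCCCC3)CC2)sc2c([N+](=O)[O-])cc(C(F)(F)F)cc12` and compound 2 `CCC(C)C(=O)N1CCN(c2nc(=O)c3cc(C(F)(F)F)cc([N+](=O)[O-])c3s2)CC1` share a core and differ only at the ring nitrogen of the attached six-membered ring. In an ADME assay on Vero cells (Chlorocebus sabaeus) for cytotoxicity, read by MTT assay, with a stated time of 72 h (a lower number here means that less compound is tolerated, a higher number that more compound is tolerated), compound 1 gives > 125000 nM, which is a limit of the measurement rather than a number. In this assay compound 2 likewise gives > 125000 nM, again a limit. The step that the two limits leave unreadable from compound 1 to compound 2 therefore cannot be sized, because of the limit of > 125000 nM in this assay, at which 2 of the 2 values shown sit.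

Compound 3 `CC(C)CC(=O)N1CCN(c2nc(=O)c3cc(C(F)(F)F)cc([N+](=O)[O-])c3s2)CC1` is the next member, and it differs from compound 1 as follows: isobutylcarbonyl in place of cyclohexylmethyl on an amine nitrogen in a ring. Within the data shown here, the only measured step that bears on this change is the one from compound 1 to compound 2, where a branched carbonyl group also replaced the cyclohexylmethyl group, and both ends of it sit at the same limit. Compound 3 carries a closely related isobutylcarbonyl group, so no step beyond the scatter is expected in this assay. Compound 3 is expected to give 150000 nM in this assay, with a range from 80000 nM to 300000 nM. The expected step that the limit leaves unreadable from compound 1 to compound 3 is essentially none, and the result will most likely again be reported as a limit.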

Compound 3, half-maximal cytotoxic concentration: > 125000 nM
Compound 3: no number, only a limit; the forecaster's own chance of this, stated with the estimate: 85%; the middle value does not contradict the limit.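

No step can be read among compound 1, compound 2 and compound 3 in this assay, because each result is a limit and not a number: the limit of > 125000 nM in this assay, at which 3 of the 3 values shown sit. As far as these compounds go, what stays open is how far the tolerated concentrations of these three compounds lie past that limit, and whether exchanging these side chains changes them at all.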